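This account rests on a few compounds, and the source may have more. Where it says the series, first, only, none or still open, it means among the compounds named here.

Compound 1, `CC[C@H]1OC(=O)[C@H](C)C(=O)[C@H](C)[C@@H](O[C@@H]2O[C@H](C)C[C@H](N(C)Cc3cccc(-c4cn(CCCCCC(=O)NO)nn4)c3)[C@H]2O)[C@@](C)(OC)C[C@@H](C)C2=NCCN3C(=O)O[C@@]1(C)[C@H]3[C@H]2C`, is a macrolide carrying a chain that ends in a hydroxamic group on a triazole; in an assay for inhibition of histone deacetylase 8 (Homo sapiens), read by mass spectrometry, with a stated time of 60 min (a lower number here means a stronger inhibitor, a higher number a weaker inhibitor), compound 1 gives 3230 nM. Compound 2, `CC[C@H]1OC(=O)[C@H](C)C(=O)[C@H](C)[C@@H](O[C@@H]2O[C@H](C)C[C@H](N(C)Cc3cccc(-c4cn(CCCCCCC(=O)NO)nn4)c3)[C@H]2O)[C@@](C)(OC)C[C@@H](C)C2=NCCN3C(=O)O[C@@]1(C)[C@H]3[C@H]2C`, differs from it by one chain carbon, and in this assay compound 2 gives 310 nM. The change is (hydroxycarbamoyl)methyl in place of hydroxycarbamoyl on a saturated chain carbon, five bonds along the chain from an aromatic nitrogen, and it produced a 10-fold lower number from compound 1 to compound 2 (1.02 log units; beyond the scatter).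

Compound 3, `CC[C@H]1OC(=O)[C@H](C)C(=O)[C@H](C)[C@@H](O[C@@H]2O[C@H](C)C[C@H](N(C)Cc3ccc(-c4cn(CC(=O)NO)nn4)cc3)[C@H]2O)[C@@](C)(OC)C[C@@H](C)C2=NCCN3C(=O)O[C@@]1(C)[C@H]3[C@H]2C`, carries the shared core with a much shorter chain and a differently substituted benzene ring; the difference between its core and that of compound 1 is not broken down here. In this assay compound 3 gives 2850 nM, close to compound 1 and far weaker than compound 2.

Compound 4, `CC[C@H]1OC(=O)[C@H](C)C(=O)[C@H](C)[C@@H](O[C@@H]2O[C@H](C)C[C@H](N(C)Cc3ccc(-c4cn(CCC(=O)NO)nn4)cc3)[C@H]2O)[C@@](C)(OC)C[C@@H](C)C2=NCCN3C(=O)O[C@@]1(C)[C@H]3[C@H]2C`, is not yet measured. It differs from compound 3 by (hydroxycarbamoyl)methyl in place of hydroxycarbamoyl on a saturated chain carbon bound to an aromatic nitrogen. This is the same kind of change as that from compound 1 to compound 2, but the place is not identical: in the earlier pair the change sits on a saturated chain carbon five bonds along the chain from an aromatic nitrogen, whereas here it sits on a saturated chain carbon bound to an aromatic nitrogen.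

Because the earlier lengthening gave a 10-fold lower number from compound 1 to compound 2 (1.02 log units; beyond the scatter), he expects compound 4 to also gain, though with less certainty given the different place, an estimated 2.9-fold lower number from compound 3 to compound 4 (0.45 log units; beyond the scatter) in this assay. His estimate for compound 4 in this assay is 1000 nM, expected to fall between 300 nM and 3500 nM.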

Compound 4, half-maximal inhibitory concentration: > 10000 nM
Compound 4 was reported as a limit; the forecaster's own chance of this, stated with the estimate: 5%; middle value at least 10-fold (1.00 log units) from the limit.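

In this assay the change that lowered the number on the core of compound 1 raised it on the core of compound 3, with an at least 3.5-fold higher number from compound 3 to compound 4 (0.54 log units; beyond the scatter), so it does not carry from one core to the other as a fixed gain: the same change on two cores in this assay, a 10-fold lower number (1.02 log units; beyond the scatter) from compound 1 to compound 2 and an at least 3.5-fold higher number (0.54 log units; beyond the scatter) from compound 3 to compound 4, at least 36-fold (1.56 log units) apart, beyond the scatter of two such steps

Compound 4 gives > 10000 nM, which is a limit of the assay and not a number.

Among the compounds shown here, with only one pair on each core, these results show that the same change can go in opposite directions, but they do not show which difference between the pairs decides the outcome, since the two pairs differ both in the place of the change along the chain and in the substitution of the benzene ring.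

The compounds shown leave open whether a longer chain on the core of compound 3 would bring its number down towards that of compound 2, and how a shorter chain would read on the core of compound 1. They also leave open whether a carboxylic acid in place of the hydroxamic group would keep any of the inhibition seen in this assay.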